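Swapping the sulfonyl aryl group on a weak growth inhibitor

The source may report more compounds than this note shows. Statements on the series, on what has been measured and on what is new or still open speak of the compounds shown alone.

Compound 1 `O=S(=O)(NCCCCCCNCc1ccc(Br)cc1)c1ccc2c(c1)OCC2` carries a bicyclic ether group on its sulfonyl sulfur, a bromobenzyl amine at the far end of a six-carbon chain. In a functional assay on MIA PaCa-2 cells (Homo sapiens) for inhibition, read by MTT assay, with a stated time of 72 h (on this read-out lower numbers stand for stronger inhibition of growth and higher numbers for weaker inhibition of growth), compound 1 gives 13000 nM, the highest number of the three measured compounds and therefore the weakest inhibition of growth among them. Compound 3 `CC(C)(C)c1ccc(S(=O)(=O)NCCCCCCNCc2ccc(Br)cc2)cc1` keeps the same chain and amine but has a tert-butylphenyl group on the sulfonyl; in this assay compound 3 gives 2970 nM, a clearly lower number. Compound 2 `O=S(=O)(NCCCNCc1ccc(-c2ccccc2)cc1)c1cc(C(F)(F)F)cc(C(F)(F)F)c1` is built on a shorter chain with a biphenylmethyl amine and a bis(trifluoromethyl)phenyl sulfonyl; in this assay compound 2 gives 2400 nM.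

Compound 4 `Cc1ccc(C)c(S(=O)(=O)NCCCCCCNCc2ccc(Br)cc2)c1` differs from compound 1 by a group of 8 heavy atoms (8 carbon; one six-membered aromatic ring of carbon only) in place of a group of 9 heavy atoms (8 carbon, 1 oxygen; one five-membered non-aromatic ring with 1 hetero atom, one six-membered aromatic ring of carbon only), on a sulfonyl sulfur. Among the compounds with values here, no direct pair of this kind has been measured. Still, a carbon-only aryl group on the sulfonyl is expected to lower the number, because compound 3 gives 2970 nM with such a group. The step from compound 1 to compound 4 is therefore expected to be a 2.6-fold lower number from compound 1 to compound 4 (0.41 log units; beyond the scatter). Compound 4 is estimated at 5000 nM, in a range from 2000 nM to 13000 nM.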

Compound 4, concentration for 50% growth inhibition: 12000 nM
Compound 4: the middle estimate sits 2.4-fold (0.38 log units) below what was measured; low and high end bracket the measured number.
By their numbers in this assay, from the lowest: compounds 2 and 3 (each within the scatter of the next); then compounds 4 and 1 (each within the scatter of the next).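

In this assay the swap to 2,5-dimethylphenyl on a sulfonyl sulfur gives a 1.1-fold lower number from compound 1 to compound 4 (0.03 log units; within the scatter) and so shows no readable difference in growth inhibition: the ring oxygen and the five-membered ring of compound 1 can go without any change this read-out can detect. A carbon-only aryl group at this position is therefore not enough for a lower number: compound 4 gives 12000 nM and compound 3, with its tert-butylphenyl group, gives 2970 nM on the same chain and amine. Nothing measured here explains this result.

On these data alone, it remains open whether the tert-butyl group itself accounts for the lower number of compound 3, and whether a plain phenyl or a pyridine ring on the sulfonyl sulfur would read like compound 3 or compound 4. As far as these compounds go, whether these sulfonyl groups behave the same way on the shorter chain of compound 2 is also open.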